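A few compounds are considered here, and "the series" means these few. Any claim that something is new, unique, unknown or untested is made for them only; others in the source may bear on it.

A small series of curcumin-like compounds was tested in a functional assay on HepG2 cells (Homo sapiens) for cytotoxicity, read by MTT assay, with a stated time of 24 h; on this read-out lower numbers stand for stronger inhibition and higher numbers for weaker inhibition. Compound 1, `COc1cc(/C=C2\CN(C)C/C(=C\c3ccc(F)cc3)C2=O)cc(OC)c1`, gives 6140 nM in this assay. Compound 2, `COc1cc(/C=C2\CN(C)C/C(=C\c3ccc(Cl)cc3)C2=O)cc(OC)c1`, carries one change from compound 1, (chloro in place of fluoro on an aromatic carbon); in this assay compound 2 gives 5950 nM, and the step of a 1.0-fold lower number from compound 1 to compound 2 (0.01 log units; within the scatter) is within the usual scatter of such measurements, so the two values cannot be told apart.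

Compound 3, `CN1C/C(=C\c2ccc(F)cc2)C(=O)/C(=C/c2ccc(C#N)cc2)C1`, has a different core, and the difference between the two cores is not broken down here. In this assay compound 3 gives 6140 nM, a value that sits within the scatter of both compound 1 and compound 2.

Compound 4, `CN1C/C(=C\c2ccc(Cl)cc2)C(=O)/C(=C/c2ccc(C#N)cc2)C1`, has not yet been measured. It differs from compound 3 by the same change seen between compound 1 and compound 2: chloro in place of fluoro on an aromatic carbon. Because the earlier step of a 1.0-fold lower number from compound 1 to compound 2 (0.01 log units; within the scatter) left the value essentially unchanged, the expected step of a 1.0-fold lower number from compound 3 to compound 4 (0.01 log units; within the scatter) is also estimated to be small. Compound 4 is therefore expected to give about 6000 nM in this assay, with the estimate likely falling between 3000 nM and 12000 nM.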

Compound 4, half-maximal inhibitory concentration: 5950 nM
For compound 4 the middle estimate is 1.0-fold (0.00 log units) above the measured one; the range from low to high includes it.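

In this assay, putting chloro in place of fluoro on the core of compound 3 gives a 1.0-fold lower number from compound 3 to compound 4 (0.01 log units; within the scatter), so the two values cannot be told apart. Set beside the same change on the core of compound 1, the two steps agree: the same change on two cores in this assay, a 1.0-fold lower number (0.01 log units; within the scatter) from compound 1 to compound 2 and a 1.0-fold lower number (0.01 log units; within the scatter) from compound 3 to compound 4, 1.0-fold (0.00 log units) apart, within the scatter of two such steps. Among these compounds, on these two cores, then, the change from 4-fluorophenyl to 4-chlorophenyl makes no visible difference to the read-out, but this rests on only two pairs of compounds, and both steps lie within the scatter, so it does not show that a change with a clear effect would carry from one core to the other.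

The compounds shown leave open whether a quite different group at the same place on the ring, such as an amine or a carboxylic acid, would move the value beyond the scatter. They also leave open whether a step of that kind would be the same size on both cores.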